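Benzyl in Place of Propylcarbonyl: Compound 2 to Compound 3

The source may report more compounds than this note shows. Statements on the series, on what has been measured and on what is new or still open speak of the compounds shown alone.

Compound 1 `COc1ccc(-c2cnc(N)nc2-c2ccccc2)cc1Cl`: > 80%
Compound 2 `CCCC(=O)Nc1ncc(-c2cccc(Cl)c2)c(-c2ccccc2)n1`: > 80%

Both measured compounds were tested in an assay on CHO cells for displacement of a labelled ligand from adenosine receptor A1 (Homo sapiens), read by scintillation counting, with a stated time of 1 h, tested at 1 uM; a higher number here means more inhibition at the concentration tested (going by the name of the read-out), a lower number less inhibition. Compound 1 gives > 80%, which is a limit of the assay rather than a number. Compound 2 gives > 80%, again a limit and not a number. The two shown values both sit at the limit of > 80% in this assay, at which 2 of the 2 values shown sit, so compound 2 stands at the top of what the assay reports, and no step between measured compounds can be read from them.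

Compound 3 `Clc1cccc(-c2cnc(NCc3ccccc3)nc2-c2ccccc2)c1` has not yet been measured in this assay. It differs from compound 2 in one place: benzyl in place of propylcarbonyl on a nitrogen on an aromatic ring. Among the compounds with values here, because compound 2 sits at the limit of > 80% in this assay, at which 2 of the 2 values shown sit, no upward step can be seen even if compound 3 inhibits as strongly. The step expected from compound 2 to compound 3 in this assay is a number at least 5 percentage points lower from compound 2 to compound 3 (that floor lies within the scatter), small and downward if anything, with a fair chance that the assay again reports only a limit. Compound 3 is thus expected to give about 75%, within a range from 45% to 92%.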

Compound 3, a percentage reported as inhibition, at one concentration (the size of the read-out at that concentration, not a potency): 16%
Compound 3: the middle estimate sits 59 percentage points above what was measured; measured number outside the range, below it.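

In this assay, the group on the nitrogen on an aromatic ring turns out to matter a great deal: benzyl in place of propylcarbonyl gives a number at least 64 percentage points lower from compound 2 to compound 3 (beyond the scatter). Compound 3 gives 16%, the first read-out shown that is a number rather than a limit, and it shows that this assay can separate compounds in this series when the group on that nitrogen changes. The true size of the step remains unknown, and the printed figure is only a bound, because the value of compound 2 is a limit: the limit of > 80% in this assay, at which 2 of the 3 values shown sit.

The change removes the carbonyl and brings in a six-membered aromatic ring in a single step, and the compounds shown do not tell which of the two goes with the loss of inhibition. A benzoyl group on the same nitrogen would keep both the carbonyl and the ring, and a butyl chain there would have neither, while compound 1 differs from compound 2 in more than one place and gives no readable step on this question.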